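Replacing the Largest Side Chain in a Three-Compound Series

The compounds below may be only part of what the source reports. "The series", "measured", "known", "first", "only" and "open" are said of these compounds alone.

Of the compounds shown here, three sharing one core have been tested in a functional assay on P388 cells (Mus musculus) for cytotoxicity; a higher number here means a weaker inhibitor, a lower number a stronger inhibitor. Compound 1 `CCCCN1C(=O)[C@@H](C)NC(=O)[C@@H]2Cc3ccc(OC)c(c3)Oc3ccc(cc3)C[C@@H](C(=O)N2C)N(C)C(=O)[C@H](C)NC(=O)[C@H](Cc2ccc(OC)cc2)N(C)C(=O)[C@@H]1C` gives 12 nM, and compound 2 `C/C=C/CN1C(=O)[C@@H](C)NC(=O)[C@@H]2Cc3ccc(OC)c(c3)Oc3ccc(cc3)C[C@@H](C(=O)N2C)N(C)C(=O)[C@H](C)NC(=O)[C@H](Cc2ccc(OC)cc2)N(C)C(=O)[C@@H]1C` gives 9.12 nM. Exchanging propyl for prop-1-en-1-yl shows a 1.3-fold lower number from compound 1 to compound 2 (0.12 log units; within the scatter). Compound 3 `COc1ccc(C[C@H]2C(=O)N[C@@H](C)C(=O)N(C)[C@H]3Cc4ccc(cc4)Oc4cc(ccc4OC)C[C@@H](C(=O)N[C@H](C)C(=O)N(C/C=C(\C)CCC=C(C)C)[C@@H](C)C(=O)N2C)N(C)C3=O)cc1` gives 49 nM, the highest number of the three, which makes it the weakest inhibitor so far. Its 2,6-dimethylhepta-1,5-dien-1-yl chain accounts for the only structural difference in a 4.1-fold higher number from compound 1 to compound 3 (0.61 log units; beyond the scatter) and in a 5.4-fold higher number from compound 2 to compound 3 (0.73 log units; beyond the scatter).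

Compound 4 `COc1ccc(C[C@H]2C(=O)N[C@@H](C)C(=O)N(C)[C@H]3Cc4ccc(cc4)Oc4cc(ccc4OC)C[C@@H](C(=O)N[C@H](C)C(=O)N(C/C=C/c4ccccc4)[C@@H](C)C(=O)N2C)N(C)C3=O)cc1` changes that same group: 2-phenylethenyl in place of 2,6-dimethylhepta-1,5-dien-1-yl on a saturated chain carbon bound to an amide-type nitrogen in a ring. Going by the values given here, no measured compound carries an aromatic ring at this place, so the evidence is indirect. Both modest steps above suggest that leaving the 2,6-dimethylhepta-1,5-dien-1-yl chain may lower the number, though 2-phenylethenyl is not a small group like propyl. A partial return is therefore expected, smaller than those steps, in this assay. The estimated change is a 2.2-fold lower number from compound 3 to compound 4 (0.35 log units; beyond the scatter). For compound 4 the estimated value is 22 nM, with an expected range of 7 nM to 70 nM.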

Compound 4, half-maximal inhibitory concentration: 10.7 nM
Compound 4: middle estimate off by 2.1-fold (0.31 log units), on the high side; the range from low to high includes it.
By their numbers in this assay, from the lowest: compounds 2, 4 and 1 (each within the scatter of the next); then compound 3.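

An aromatic ring is accepted at this place in this assay: the step of a 1.2-fold higher number from compound 2 to compound 4 (0.07 log units; within the scatter) and the step of a 1.1-fold lower number from compound 1 to compound 4 (0.05 log units; within the scatter) both leave compound 4 level with the compounds carrying the small chains. The step of a 4.6-fold lower number from compound 3 to compound 4 (0.66 log units; beyond the scatter) adds that the heavy-atom count of the group does not alone set the number, since 2-phenylethenyl has 8 heavy atoms against 9 for 2,6-dimethylhepta-1,5-dien-1-yl, yet only compound 3 stands apart. No supporting measurement is available to explain why these two large groups differ.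

Still open, on these data alone, is whether the ring itself matters here, or whether a cyclohexyl ring in place of the phenyl would give the same number. As far as these compounds go, it is also open how a chain ending in an amine or a carboxylic acid would fare at this place.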